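Replacing the tert-butoxycarbonyl group of compound 3

The source may report more compounds than this note shows. Statements on the series, on what has been measured and on what is new or still open speak of the compounds shown alone.

In a functional assay (strain AB) with Danio rerio as the target, read by microscopy, with a stated time of 1 h (a higher number here means that more compound is needed for the effect, a lower number that less compound is needed), compound 1 `CC(C)(C)OC(=O)CCN1CCc2c(sc(NC(=O)Nc3ccc(Cl)cc3)c2C(N)=O)C1` gives 1100 nM, compound 2 `COCCCN1CCc2c(sc(NC(=O)Nc3ccc(Cl)cc3)c2C(N)=O)C1` gives 2400 nM and compound 3 `CC(C)(C)OC(=O)CCCN1CCc2c(sc(NC(=O)Nc3ccc(Cl)cc3)c2C(N)=O)C1` gives 560 nM. Compound 3 stands level with compound 1, as a 2.0-fold lower number from compound 1 to compound 3 (0.29 log units; within the scatter) shows, and under compound 2. Compound 4 `NC(=O)c1c(NC(=O)Nc2ccc(Cl)cc2)sc2c1CCN(CCCNC(=O)CCc1cccnc1)C2` differs from it in one place: ((2-(pyridin-3-yl)ethyl)carbonyl)amino in place of tert-butoxycarbonyl on a saturated chain carbon, three bonds along the chain from an amine nitrogen in a ring. Within the data shown here, the only measured swap at this place is a 4.3-fold lower number from compound 2 to compound 3 (0.63 log units; beyond the scatter), so losing tert-butoxycarbonyl may raise the number by a modest step. The step of a 2.2-fold higher number from compound 1 to compound 2 (0.34 log units; beyond the scatter) points the same way. Among the measured compounds shown here, no measured compound carries the entering group, so the uncertainty is wide. The expected change is a 2.3-fold higher number from compound 3 to compound 4 (0.37 log units; beyond the scatter), a modest one in this assay. The estimate for compound 4 is 1300 nM, with an expected range from 350 nM to 5000 nM.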

Compound 4, half-maximal effective concentration: 470 nM
Compound 4: the middle estimate sits 2.8-fold (0.44 log units) above what was measured, and the stated range covers the measured number.
By their numbers in this assay, from the lowest: compounds 4, 3 and 1 (each within the scatter of the next, the first and the last beyond it); then compound 2.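

In this assay the chain end takes a larger group carrying an aromatic ring and a hydrogen-bond donor, ((2-(pyridin-3-yl)ethyl)carbonyl)amino, with no real change from tert-butoxycarbonyl (a 1.2-fold lower number from compound 3 to compound 4 (0.08 log units; within the scatter)). So tert-butoxycarbonyl is not needed here for a low number. Methoxy does not match this group (a 5.1-fold lower number from compound 2 to compound 4 (0.71 log units; beyond the scatter)), and the new chain end also stands clear of the shorter ester (a 2.3-fold lower number from compound 1 to compound 4 (0.37 log units; beyond the scatter)).

Nothing available explains these differences. Going by these compounds, whether a simple amine, a carboxylic acid or a phenyl ring in place of the pyridine ring would keep the number this low remains open.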